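The source may hold more compounds than are shown below. What is called first, only, known or untested is meant among the compounds shown, and "the series" means these compounds.

Compound 3 `O=C(/C=C/c1ccc(NC(=O)Nc2ccc(Cl)c(C(F)(F)F)c2)cc1)NC1CCC1` sits at the lowest of the three numbers in a functional assay on KETR3 cells (Homo sapiens) for inhibition, read by MTT assay, with a stated time of 120 h (a higher number here means a weaker inhibitor, a lower number a stronger inhibitor), where compound 3 gives 17300 nM. Compound 1 `CC(NC(=O)C#Cc1ccc(NC(=O)Nc2cc(C(F)(F)F)ccc2Cl)cc1)c1ccccc1` gives 23200 nM, a gap within the scatter, so no order between compound 1 and compound 3 is claimed. Compound 2 `CC1CN(C(=O)c2ccc(-c3ccc(NC(=O)Nc4ccc(Cl)c(C(F)(F)F)c4)cc3)cc2)CC(C)O1` gives 41900 nM, a gap beyond the scatter from compound 3. No pair among these three differs in a single place, so nothing measured here shows what a change on the amide-type nitrogen brings. Compound 4 `CNC(=O)/C=C/c1ccc(NC(=O)Nc2ccc(Cl)c(C(F)(F)F)c2)cc1` differs from compound 3 by methyl in place of cyclobutyl on an amide-type nitrogen. The change is expected to give a small step, probably none beyond the scatter, with a slight lean towards a higher number. Compound 4 is estimated at 25000 nM in this assay, with a range from 10000 nM to 60000 nM. The expected step is a 1.4-fold higher number from compound 3 to compound 4 (0.16 log units; within the scatter).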

Compound 4, half-maximal inhibitory concentration: 21200 nM
Compound 4: the middle estimate sits 1.2-fold (0.07 log units) above what was measured; low and high end bracket the measured number.
By their numbers in this assay, from the lowest: compounds 3, 4, 1 and 2 (each within the scatter of the next, the first and the last beyond it).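

Going by these compounds alone, on the amide-type nitrogen, methyl in place of cyclobutyl gives a 1.2-fold higher number from compound 3 to compound 4 (0.09 log units; within the scatter) in this assay, the first comparison that differs in one place. At this position, the cyclobutyl ring and its four carbons can thus give way to a single methyl without a step beyond the scatter, so compound 3 and compound 4 cannot be told apart here. Nothing available bears on why the two groups read alike. From the compounds shown here alone, what a longer chain, an amine or a carboxylic acid on this nitrogen would bring remains open. Going by these compounds, whether any group at this position can give a step beyond the scatter also remains open.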